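The source may report more compounds than this note shows. Statements on the series, on what has been measured and on what is new or still open speak of the compounds shown alone.

In a functional assay on MDCK cells (Canis lupus familiaris) for inhibition (on this read-out higher numbers stand for lower toxicity in this test and lower numbers for higher toxicity in this test), compound 1 `C[C@H]1O[C@@]1(C)Cc1cc(=O)n(C)c(=O)n1C` gives 89000 nM and compound 2 `Cn1c(CC23CCCC[C@@H]2O3)cc(=O)n(C)c1=O` gives 40000 nM in the same test. Compound 3 `Cn1c(C[C@]2(C)CCCO2)cc(=O)n(C)c1=O` stands highest of the three at 1380000 nM and lies beyond the scatter from both others. Compound 4 `Cn1c(C[C@]2(c3ccccc3)CCCO2)cc(=O)n(C)c1=O` carries phenyl in place of methyl on a saturated ring carbon, with phenyl in place of methyl on a saturated ring carbon as the counted change. Among the measured compounds shown here, no measured pair shows such a swap, so the expectation rests only on compound 3 at 1380000 nM as the top of a small set: a fall in this assay toward the other two is expected, beyond the scatter. The estimated step is a 6.9-fold lower number from compound 3 to compound 4 (0.84 log units; beyond the scatter) in that direction. For compound 4 the estimated value is 200000 nM with 40000 nM to 900000 nM as the expected range.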

Compound 4, half-maximal cytotoxic concentration: 547000 nM
Beside the measured number, compound 4's estimate is 2.7-fold (0.44 log units) below it; the range from low to high includes it.
By their numbers in this assay, from the lowest: compound 2; then compound 1; then compound 4; then compound 3.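

Phenyl in place of methyl on a saturated ring carbon, next to the ring oxygen, gives a 2.5-fold lower number from compound 3 to compound 4 (0.40 log units; beyond the scatter) in this assay. Among the compounds shown here, this is the first step read at this position: one six-membered aromatic ring of carbon only enters, and the toxicity read-out moves modestly, though beyond the scatter. Nothing at hand explains the shift.

Open, from the compounds shown here alone, is whether an ethyl or longer chain at this carbon would give a step of similar size. Also open, going by these compounds, is how a carboxylic acid or an amine on the phenyl would move the number.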